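Stereoisomers of a furanoid butenolide: cytotoxicity in ovarian cells

The compounds below may be only part of what the source reports. "The series", "measured", "known", "first", "only" and "open" are said of these compounds alone.

Measured compounds:
compound 1, `CC1=C(O)[C@@H](C/C(C)=C\CCC(C)/C=C/C=C(\C)CCCc2ccoc2)OC1=O`, 22.1 ug/mL
compound 2, `CC1=C(O)[C@@H](C/C(C)=C\CCC(C)/C=C/C/C(C)=C/CCc2ccoc2)OC1=O`, 26.8 ug/mL

In a functional assay on SK-OV-3 cells (Homo sapiens) for cytotoxicity (a lower number here means that less compound is needed, a higher number that more compound is needed for the effect), compound 1 gives the lowest of the two numbers, and compound 2 sits within the scatter of it, so neither can be called the more active. Compound 3, `CC1=C(O)[C@H](C/C(C)=C\CCC(C)/C=C\C=C(\C)CCCc2ccoc2)OC1=O`, has not yet been measured. It is a stereoisomer of compound 1: the two compounds have the same atoms and bonds; at least one stereo element is drawn with a configuration in one of them and without one in the other: 3 of 5 stereo elements differ; a stereocentre at a saturated ring carbon is drawn R in compound 1 and S in compound 3; a double bond is drawn E in compound 1 and Z in compound 3; a double bond is drawn E in compound 1 and Z in compound 3. Among the compounds with values here, no step between measured compounds shows what such a change does here, so compound 3 is expected to land near compound 1, with a 1.4-fold higher number from compound 1 to compound 3 (0.13 log units; within the scatter) as the estimated step, leaning toward a somewhat higher number but not clearly beyond the scatter. For compound 3 the estimated value is 30 ug/mL, within 12 ug/mL to 75 ug/mL.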

Compound 3, concentration for half-maximal effect: 11.3 ug/mL
Beside the measured number, compound 3's estimate is 2.7-fold (0.42 log units) above it; the measured number lies below the stated range.
By their numbers in this assay, from the lowest: compounds 3, 1 and 2 (each within the scatter of the next, the first and the last beyond it).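

In this assay, within the data shown here, the first stereochemical comparison gives a 2.0-fold lower number from compound 1 to compound 3 (0.29 log units; within the scatter). Moving the saturated ring carbon from R to S while two double bonds go from E to Z therefore does not take the number beyond the scatter, even with three stereo elements differing at once. The reading carries a caveat, since the two drawings are not equally defined: the fact that one of compounds 1 and 3 is drawn with a defined configuration and the other without, at the place where they differ

The three changes come together, so the contribution of the ring carbon and of each double bond remains unresolved. Also open, from the compounds shown here alone, is what an amine or a carboxylic acid on the shared core would do to the number.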